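Chloro on the Sulfur-Bearing Ring: One Change, Two Cores

The source may hold more compounds than are shown below. What is called first, only, known or untested is meant among the compounds shown, and "the series" means these compounds.

Compound 1 `CC(O)(CS(=O)(=O)c1ccccc1)c1nc(-c2ccccc2)no1` and compound 2 `CC(O)(CS(=O)(=O)c1ccccc1)c1nc(-c2ccc(Cl)cc2)no1` share one core, and compound 3 `CC(O)(CSc1ccccc1)c1nc(-c2ccc([N+](=O)[O-])c(C(F)(F)F)c2)no1` belongs to another; how the two cores differ is not broken down here. The two cores were tested in a functional assay on DU-145 cells (Homo sapiens) for cytotoxicity, read by MTT assay; a lower number here means a stronger inhibitor, a higher number a weaker inhibitor. In this assay compound 1 gives > 100000 nM, which is a limit of the assay and not a number. In this assay compound 2 likewise gives > 100000 nM, again a limit rather than a number. The change between them is chloro in place of hydrogen on an aromatic carbon, and the step that the two limits leave unreadable from compound 1 to compound 2 cannot be read, because both values sit at the limit of > 100000 nM in this assay, at which 2 of the 3 values shown sit. Among the compounds with values here, compound 3 stands apart: in this assay compound 3 gives 3000 nM, the only number among the three values.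

Compound 4 `CC(O)(CSc1ccc(Cl)cc1)c1nc(-c2ccc([N+](=O)[O-])c(C(F)(F)F)c2)no1` has not been measured. It differs from compound 3 by chloro in place of hydrogen on an aromatic carbon, the same change that separates compound 1 from compound 2, occurring twice among these compounds. Within the data shown here, the single earlier instance of this change gives no readable size, so nothing measured argues for a shift in either direction from compound 3 to compound 4. On that basis the step of no change at the digits printed from compound 3 to compound 4 (within the scatter) is expected to lie within the usual scatter. In this assay compound 4 is therefore expected to give about 3000 nM, with a plausible range from 1000 nM to 9000 nM.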

Compound 4, half-maximal inhibitory concentration: 1300 nM
The estimate for compound 4 lay 2.3-fold (0.36 log units) above the measured number; measured number inside the range.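

In this assay, chloro in place of hydrogen on the core of compound 3 gives a 2.3-fold lower number from compound 3 to compound 4 (0.36 log units; beyond the scatter), a modest step and the only readable size for this change among the compounds shown. The same change on the core of compound 1 cannot be read, because the values of compound 1 and compound 2 are limits of the assay and not numbers: the limit of > 100000 nM in this assay, at which 2 of the 4 values shown sit. The result therefore shows that the change lowers the number on one core, but not that this effect carries from one core to another, and the chloro of compound 2 also stands on a different aromatic ring from the sulfur-bearing ring that carries it in compound 4.

The compounds shown leave open whether another group in the place of this chloro on the sulfur-bearing ring, such as bromo, methoxy or an amine, would move the number in the same way as chloro. They also leave open whether the nitro and trifluoromethyl groups of compound 3 and compound 4 could give way to a carboxylic acid or an amine on that other ring with a number still readable.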